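Phenyl to cyclohexylmethyl on the shared core

The source may report more compounds than this note shows. Statements on the series, on what has been measured and on what is new or still open speak of the compounds shown alone.

Going by the values given here, in a physicochemical assay for solubility, with a stated time of 18 h, at pH 7.4 (on this read-out higher numbers stand for higher solubility and lower numbers for lower solubility), compound 2 `COc1cccc(CNCCCNc2ccnc3cc(-c4ccccc4)ccc23)c1O` gives 32000 nM, the higher of the two numbers so far, while compound 1 `COc1cccc(CNCCCNc2ccnc3cc(C4CCCCC4)ccc23)c1O` gives 4200 nM. Compound 3 `COc1cccc(CNCCCNc2ccnc3cc(CC4CCCCC4)ccc23)c1O` differs from compound 2 by cyclohexylmethyl in place of phenyl on an aromatic carbon. Among the compounds with values here, the one measured step bearing on this is phenyl in place of cyclohexyl, a 7.6-fold higher number from compound 1 to compound 2 (0.88 log units; beyond the scatter), which is beyond the scatter and modest. Run in reverse, it suggests a drop of similar size in this assay. The expected change is a 9.1-fold lower number from compound 2 to compound 3 (0.96 log units; beyond the scatter). Compound 3 is estimated at 3500 nM, within a range of 1200 nM to 10000 nM.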

Compound 3, solubility: 4200 nM
The estimate for compound 3 lay 1.2-fold (0.08 log units) below the measured number; the range from low to high includes it.
By their numbers in this assay, from the lowest: compounds 1 and 3 (each within the scatter of the next); then compound 2.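

In this assay, cyclohexylmethyl in place of phenyl gives a 7.6-fold lower number from compound 2 to compound 3 (0.88 log units; beyond the scatter) on this position of the shared core, so phenyl now stands apart from two non-aromatic carbon rings rather than one. Cyclohexylmethyl in place of cyclohexyl gives no change at the digits printed from compound 1 to compound 3 (within the scatter) in this assay and so separates neither compound from the other. Nothing available accounts for either step.

Open, on these data alone, is whether benzyl, which joins the aromatic ring to the same position through a single carbon, would read like phenyl or like cyclohexylmethyl. Also open, as far as these compounds go, is how a ring carrying an amine or a carboxylic acid would read here.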